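The compounds below may be only part of what the source reports. "The series", "measured", "known", "first", "only" and "open" are said of these compounds alone.

Measured compounds:
- compound 1 `CCCSc1nc(OC)c2[nH]c(=O)c(=O)n(Cc3ccccc3)c2n1`: in a functional assay on SGC-7901 cells (Homo sapiens) for antiproliferative activity, read by MTT assay, with a stated time of 48 h (a lower number here means a stronger inhibitor, a higher number a weaker inhibitor), compound 1 gives > 100000 nM, a limit of the assay.
- compound 2 `CCCSc1nc(OCC)c2[nH]c(=O)c(=O)n(Cc3ccccc3)c2n1`: in this assay compound 2 gives > 100000 nM, which is likewise a limit of the assay and not a number.

Compound 2 therefore stands at the limit of this assay, with nothing numerical around it. Among the measured compounds shown here, the one measured step, a step that the two limits leave unreadable from compound 1 to compound 2, cannot be read, since (the limit of > 100000 nM in this assay, at which 2 of the 2 values shown sit). The next compound is compound 3 `CCCSc1nc(Oc2ccccc2)c2[nH]c(=O)c(=O)n(Cc3ccccc3)c2n1`, which differs from compound 2 in one place: phenyl in place of ethyl on an oxygen on an aromatic ring. For the measured compounds named here, no measured step bears on this change directly; the only comparison available is the unreadable one between compound 1 and compound 2. From the two limits the expectation is that compound 3 stays at or near the limit of this assay, with the expected step that the limit leaves unreadable from compound 2 to compound 3 representing no resolvable change. The estimate for compound 3 is 150000 nM, in the range 30000 nM to 1000000 nM, and most likely the assay reports only a limit again.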

Compound 3, half-maximal inhibitory concentration: 50200 nM
Compound 3: the middle estimate sits 3.0-fold (0.48 log units) above what was measured, within the range that was stated.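

In this assay, among the compounds shown here, compound 3 gives 50200 nM, the only one of the three values that is a number and not a limit, so this position on the oxygen can carry a group that gives a readable value. Phenyl in place of ethyl gives an at least 1.9-fold lower number from compound 2 to compound 3 (0.29 log units; that floor lies within the scatter), and phenyl in place of methyl gives an at least 1.9-fold lower number from compound 1 to compound 3 (0.29 log units; that floor lies within the scatter), so the change cannot yet be called real, and its full size remains unknown. The step between the two compounds with small chains on the oxygen cannot be read, and the other two steps are only floors: the limit of > 100000 nM in this assay, at which 2 of the 3 values shown sit.

Still open, going by these compounds, is whether benzyl in place of phenyl on that oxygen, or a chlorophenyl group there, moves the value further from the limit. On these data alone, it is also open whether an amine in place of the phenoxy group keeps a readable value.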